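The source may hold more compounds than are shown below. What is called first, only, known or untested is meant among the compounds shown, and "the series" means these compounds.

Measured in a functional assay on HepG2 cells (Homo sapiens) for antiproliferative activity, read by sulforhodamine B assay, with a stated time of 48 h; a lower number here means a stronger inhibitor, a higher number a weaker inhibitor:
- compound 1 `COc1cccc(/C=C/C(=O)C(=Cc2cc(OC)c(OC)c(OC)c2)C(=O)/C=C/c2cccc(OC)c2OC)c1OC`: 220 nM
- compound 2 `COc1cc(C=C(C(=O)/C=C/c2cccc(OC)c2OC)C(=O)/C=C/c2cccc(OC)c2OC)cc(OC)c1O`: 210 nM

Among the compounds with values here, compound 2 stands within the scatter of compound 1, the only other measured compound, so it holds no real lead.

Compound 3 `COc1cccc(/C=C/C(=O)C(=Cc2ccc(OC)c(OC)c2OC)C(=O)/C=C/c2cccc(OC)c2OC)c1OC` follows from compound 2 by 2,3,4-trimethoxyphenyl in place of 4-hydroxy-3,5-dimethoxyphenyl on a double-bonded chain carbon bound to a double-bonded chain carbon. Within the data shown here, one measured step bears on this: a 1.0-fold lower number from compound 1 to compound 2 (0.02 log units; within the scatter), for hydrogen in place of methyl on an oxygen on an aromatic ring. That step covers only part of the change. Among the measured compounds shown here, no measured step tests a new arrangement of groups on the ring, so the uncertainty stays wide.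

An expected 1.2-fold higher number from compound 2 to compound 3 (0.09 log units; within the scatter) amounts to no step beyond the scatter in this assay. For compound 3 the estimated value is 260 nM, with an expected range of 100 nM to 700 nM.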

Compound 3, half-maximal inhibitory concentration: 240 nM
Compound 3: the middle estimate sits 1.1-fold (0.03 log units) above what was measured, within the range that was stated.
By their numbers in this assay, from the lowest: compounds 2, 1 and 3 (each within the scatter of the next).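

In this assay, 2,3,4-trimethoxyphenyl on a double-bonded chain carbon bound to a double-bonded chain carbon gives a 1.1-fold higher number from compound 2 to compound 3 (0.06 log units; within the scatter) and a 1.1-fold higher number from compound 1 to compound 3 (0.04 log units; within the scatter). The earlier pair tested only hydrogen in place of methyl on one ring oxygen, whereas these steps add a different placement of the ring substituents, and the number still does not move beyond the scatter, with or without the hydrogen-bond donor counted in 4-hydroxy-3,5-dimethoxyphenyl. No supporting data are available to explain this flat result.

Going by these compounds, all three compounds carry only methoxy or hydroxy groups on this ring, so it remains open whether an amine or a carboxylic acid there would shift the number beyond the scatter. The shared remainder of the core is also untested, as it stays the same across compounds 1, 2 and 3.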